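Swapping a halogen for a nitro group on the triazole arm

The source may hold more compounds than are shown below. What is called first, only, known or untested is meant among the compounds shown, and "the series" means these compounds.

Among the compounds with values here, compound 2 `O=c1ccoc2cc(OCc3cn(Cc4cccc([N+](=O)[O-])c4)nn3)ccc12` gives the lowest number of the two so far in a functional assay on HeLa cells (Homo sapiens) for cytotoxicity, read by MTT assay, with a stated time of 48 h (a higher number here means a weaker inhibitor, a lower number a stronger inhibitor), at 17300 nM. Compound 1 `O=c1ccoc2cc(OCc3cn(Cc4ccc(Cl)cc4)nn3)ccc12` gives 37600 nM. Within the data shown here, the one measured step, a 2.2-fold lower number from compound 1 to compound 2 (0.34 log units; beyond the scatter), is modest yet beyond the scatter. Compound 3 `O=c1ccoc2cc(OCc3cn(Cc4ccc(Br)cc4)nn3)ccc12` carries a change that runs back toward a halogen: 4-bromophenyl in place of 3-nitrophenyl on a saturated chain carbon bound to an aromatic nitrogen. Because that earlier step a 2.2-fold lower number from compound 1 to compound 2 (0.34 log units; beyond the scatter) went the other way, the expectation for compound 3 is a modest rise in this assay, a 2.0-fold higher number from compound 2 to compound 3 (0.31 log units; beyond the scatter), putting compound 3 at an estimated 35000 nM, within 15000 nM to 80000 nM.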

Compound 3, half-maximal inhibitory concentration: > 100000 nM
Compound 3 gave a limit, no number (the forecaster's own chance of this, stated with the estimate: 10%); at least 2.8-fold (0.45 log units) between middle value and limit.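

Even a swap from one halogen to another counts at this position: bromo in place of chloro gives an at least 2.6-fold higher number from compound 1 to compound 3 (0.42 log units; beyond the scatter) in this assay. Moving from the 3-nitrophenyl to the 4-bromophenyl gives an at least 5.7-fold higher number from compound 2 to compound 3 (0.76 log units; beyond the scatter), so this change reverses the gain seen earlier and goes further. The result for compound 3 is a limit of the assay, not a number: the limit of > 100000 nM in this assay, at which 1 of the 3 values shown sits.

From the compounds shown here alone, how large these two new steps really are stays open. So does whether an amine or a carboxylic acid on the same phenyl ring would give a lower number than compound 2.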